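Adding acetamido to the benzyl group of compound 2

The source may hold more compounds than are shown below. What is called first, only, known or untested is meant among the compounds shown, and "the series" means these compounds.

Measured in a functional assay on B16-F1 cells (Mus musculus) for antiproliferative activity, read by sulforhodamine B assay, with a stated time of 48 h; a lower number here means a stronger inhibitor, a higher number a weaker inhibitor:
- compound 1 `CCCCCCCCCCCCCCCCNC(=O)[C@@H]1CNC(c2ccc(NC(C)=O)cc2)=N1`: 2400 nM
- compound 2 `CCCCCCCCCCCCCCCCNC(=O)[C@@H]1CSC(Cc2ccccc2)N1`: 6500 nM
- compound 3 `CCCCCCCCC/C=C/CCCCCCCNC(=O)[C@@H]1CSC(Cc2ccccc2)N1`: 11600 nM

Compound 2 stands within the scatter of compound 3, while compound 1 gives a lower number, beyond the scatter. Next comes compound 4 `CCCCCCCCCCCCCCCCNC(=O)[C@@H]1CSC(Cc2ccc(NC(C)=O)cc2)N1`, with acetamido in place of hydrogen on an aromatic carbon, para to a large group: benzyl to 4-acetamidobenzyl. Going by the values given here, the only measured step, a 1.8-fold higher number from compound 2 to compound 3 (0.25 log units; within the scatter), lies in the chain and leaves the aromatic ring unchanged, so it offers little guidance here. Compound 1 carries the 4-acetamidophenyl group on a different core and gives 2400 nM, which suggests only a modest shift towards lower numbers in this assay. The expected step is a 1.7-fold lower number from compound 2 to compound 4 (0.23 log units; within the scatter). For compound 4 the estimated value is 3800 nM, with an expected range of 1300 nM to 10000 nM.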

Compound 4, half-maximal inhibitory concentration: 171000 nM
Compound 4: middle estimate off by 45-fold (1.65 log units), on the low side, outside the stated range (above it).
By their numbers in this assay, from the lowest: compound 1; then compounds 2 and 3 (each within the scatter of the next); then compound 4.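

In this assay, benzyl to 4-acetamidobenzyl gives a 26-fold higher number from compound 2 to compound 4 (1.42 log units; beyond the scatter), so on this core the aromatic carbon is a sensitive place for substitution. The chain change, by contrast, gives a 1.8-fold higher number from compound 2 to compound 3 (0.25 log units; within the scatter), so among these compounds only the ring change moves the number beyond the scatter. Nothing measured here accounts for the rise. On these data alone, with one substituent at this position, it remains open whether the loss belongs to acetamido alone. A free amine or fluorine in the same place would test this.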